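A few compounds are considered here, and "the series" means these few. Any claim that something is new, unique, unknown or untested is made for them only; others in the source may bear on it.

Measured so far in a functional assay on HT-29 cells (Homo sapiens) for inhibition, read by luminescence and CellTiter-Glo, with a stated time of 24 h; on this read-out higher numbers stand for an effect only at larger amounts of compound and lower numbers for an effect already at smaller amounts:
- compound 1 `CN1C(=S)[C@@H](NC(=O)c2nc(Cc3ccccc3)n(C)n2)COc2ccccc21` gives 2.5 nM
- compound 2 `CCCn1nc(C(=O)N[C@H]2COc3ccccc3N(C)C2=S)nc1Cc1ccccc1` gives 288 nM
- compound 3 `CC(C)n1nc(C(=O)N[C@H]2COc3ccccc3N(C)C2=S)nc1Cc1ccccc1` gives 360 nM

Compound 3 sits with compound 2 at the high-number end of this small set. The two lie within the scatter of each other, and both are far from compound 1. The next compound is compound 4 `CC(C)Cn1nc(C(=O)N[C@H]2COc3ccccc3N(C)C2=S)nc1Cc1ccccc1`, which carries isobutyl in place of isopropyl on an aromatic nitrogen.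

Within the data shown here, three measured steps bear on this change. Going from methyl to propyl on that nitrogen gave a large step (a 120-fold higher number from compound 1 to compound 2 (2.06 log units; beyond the scatter)), and going from methyl to isopropyl gave another (a 140-fold higher number from compound 1 to compound 3 (2.16 log units; beyond the scatter)). Propyl and isopropyl, however, do not separate (a 1.3-fold higher number from compound 2 to compound 3 (0.10 log units; within the scatter)). Among the measured compounds shown here, no isobutyl compound has been measured, so the expectation rests on these three compounds alone. The change at hand starts from isopropyl, not methyl, so the comparison between compound 2 and compound 3 is the closer guide, and no step beyond the scatter is expected in this assay. The estimated step is small (a 1.1-fold higher number from compound 3 to compound 4 (0.05 log units; within the scatter)). Compound 4 is expected at 400 nM, with an estimated range from 130 nM to 1200 nM in this read-out.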

Compound 4, half-maximal effective concentration: 1230 nM
Compound 4: the middle estimate sits 3.1-fold (0.49 log units) below what was measured; measured number above the stated range.
By their numbers in this assay, from the lowest: compound 1; then compounds 2 and 3 (each within the scatter of the next); then compound 4.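

In this assay this position, which gave no separation between propyl and isopropyl, does respond to isobutyl in place of isopropyl on the aromatic nitrogen (a 3.4-fold higher number from compound 3 to compound 4 (0.53 log units; beyond the scatter)). Against the straight propyl chain the added methyl on the saturated chain carbon also counts (a 4.3-fold higher number from compound 2 to compound 4 (0.63 log units; beyond the scatter)), so the position tells these chains apart, although the two modest steps remain small beside the large change from the methyl group on that nitrogen (a 490-fold higher number from compound 1 to compound 4 (2.69 log units; beyond the scatter)). No measured finding on these compounds accounts for the difference between isobutyl and the two smaller chains.

As far as these compounds go, how the number runs between methyl and propyl remains open, as an ethyl group on this nitrogen would show, and so does whether it keeps rising with a longer chain such as pentyl. Also open, from the compounds shown here alone, is whether a cyclopropyl group or a chain ending in an amine or a carboxylic acid on the same nitrogen would follow these alkyl groups, and whether the steps hold when the benzyl group on the neighbouring ring atom is changed.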